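Series notes: bromo in place of methoxy

The source may hold more compounds than are shown below. What is called first, only, known or untested is meant among the compounds shown, and "the series" means these compounds.

Within the data shown here, compound 3 `COC(=O)c1ccc(OC)c(CSc2nc3ccccc3n2CC(=O)O)c1` gives 29 nM in an assay on HEK293 cells for displacement of a labelled ligand from prostaglandin D2 receptor 2 (Homo sapiens) (a higher number here means a weaker inhibitor, a lower number a stronger inhibitor), and stands lowest of the three numbers so far; compound 2 `COC(=O)c1cccc(CSc2nc3ccccc3n2CC(=O)O)c1` gives 450 nM and compound 1 `O=C(O)Cn1c(SCc2ccccc2Br)nc2ccccc21` gives 580 nM in the same assay. Among the measured compounds shown here, the step from compound 2 to compound 3 was a 16-fold lower number from compound 2 to compound 3 (1.19 log units; beyond the scatter) and is the only measured change at this aromatic carbon. Compound 4 `COC(=O)c1ccc(Br)c(CSc2nc3ccccc3n2CC(=O)O)c1` differs from compound 3 by bromo in place of methoxy on an aromatic carbon. For the measured compounds named here, no measured step sets bromo against methoxy; the step of a 16-fold lower number from compound 2 to compound 3 (1.19 log units; beyond the scatter) shows only that the methoxy carried a large gain, so its loss risks giving part of that back, while bromo at this carbon is untested. A modest rise in this assay is therefore expected for compound 4 a 4.1-fold higher number from compound 3 to compound 4 (0.62 log units; beyond the scatter) with a wide range. The estimate for compound 4 is 120 nM with a range from 30 nM to 500 nM in this assay.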

Compound 4, half-maximal inhibitory concentration: 45 nM
Compound 4: middle estimate off by 2.7-fold (0.43 log units), on the high side, and the stated range covers the measured number.
By their numbers in this assay, from the lowest: compounds 3 and 4 (each within the scatter of the next); then compounds 2 and 1 (each within the scatter of the next).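

In this assay, bromo in place of methoxy on this aromatic carbon gives a 1.6-fold higher number from compound 3 to compound 4 (0.19 log units; within the scatter), so the two groups are not separated here. Bromo in place of hydrogen gives a 10-fold lower number from compound 2 to compound 4 (1.00 log units; beyond the scatter), so the large gain at this carbon is not confined to methoxy. Methoxycarbonyl in place of hydrogen, with bromo present, gives a 13-fold lower number from compound 1 to compound 4 (1.11 log units; beyond the scatter), so both substituents matter together in compound 4.

No supporting evidence bears on the reason for these steps. Going by these compounds, whether an amine or a hydroxyl group at this carbon would hold the number remains open, as does the effect of a carboxylic acid in place of the methoxycarbonyl group.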